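Replacing the 4-Hydroxybutyl Chain: What Compound 4 Might Show

The source may hold more compounds than are shown below. What is called first, only, known or untested is meant among the compounds shown, and "the series" means these compounds.

Compound 1 `O=c1cc(Cn2cc(CCCCO)nn2)c2ccc(O)cc2o1` sits at the limit > 100000 nM in a functional assay on HepG2 cells (Homo sapiens) for inhibition, read by MTT assay, with a stated time of 72 h; on this read-out lower numbers stand for stronger inhibition and higher numbers for weaker inhibition; this value is a limit, not a number.
Compound 2 `CC(C)(C)c1cn(Cc2cc(=O)oc3cc(O)ccc23)nn1` also sits at the limit > 100000 nM in this assay.
Compound 3 `O=c1cc(Cn2cc(-c3cc(F)cc(F)c3)nn2)c2ccc(O)cc2o1` gives 38900 nM in this assay.

Compound 1 therefore stands at a boundary of the measurement rather than at a number, and the same is true of compound 2 (the limit of > 100000 nM in this assay, at which 2 of the 3 values shown sit). Compound 4 `O=c1cc(Cn2cc(CSC(=S)N3CCNCC3)nn2)c2ccc(O)cc2o1` differs from compound 1 by a group of 9 heavy atoms (5 carbon, 2 nitrogen, 2 sulfur; one six-membered non-aromatic ring with 2 hetero atoms) in place of a group of 4 heavy atoms (3 carbon, 1 oxygen; no ring), on a saturated chain carbon bound to an aromatic carbon. Among the measured steps, two touch the same position: from the 4-hydroxybutyl chain to a tert-butyl group the step that the two limits leave unreadable from compound 1 to compound 2 cannot be read, while the step of an at least 2.5-fold lower number from compound 1 to compound 3 (0.41 log units; beyond the scatter) is at least modest, and so is an at least 2.5-fold lower number from compound 2 to compound 3 (0.41 log units; beyond the scatter). None of these introduces a group resembling what enters in compound 4, so they give only a loose anchor: a change at this position can move the number downward out of the limit, but need not. On that basis compound 4 is expected to land near 80000 nM, with a plausible range from 20000 nM to 300000 nM in this assay, and the step of an at least 1.2-fold lower number from compound 1 to compound 4 (0.09 log units; that floor lies within the scatter) is the expected outcome, with a real chance that only a limit is reported again.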

Compound 4, half-maximal inhibitory concentration: > 100000 nM
Compound 4 gave a limit, no number; the forecaster's own chance of this, stated with the estimate: 55%; middle value at least 1.2-fold (0.09 log units) away from the limit.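

In this assay, within the data shown here, compound 4 gives only a limit, not a number, as compound 1 does, so no step from one to the other can be read, and the result joins the crowd at the boundary: the limit of > 100000 nM in this assay, at which 3 of the 4 values shown sit. From the compounds shown here alone, how far compounds 1, 2 and 4 truly lie from one another stays open, as does how any of them compares numerically with compound 3.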